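Fluorine on the Core: From Compound 1 to Compound 3

A few compounds are considered here, and "the series" means these few. Any claim that something is new, unique, unknown or untested is made for them only; others in the source may bear on it.

Measured compounds:
compound 1 `CSc1cc(C)[nH]c(=O)c1CNC(=O)c1c(C)n([C@H](C)[C@H]2CC[C@H](N3CC(OC4CC4)C3)CC2)c2ncccc12`: 1.8 nM
compound 2 `CSc1cc(C)[nH]c(=O)c1CNC(=O)c1c(C)n([C@H](C)[C@H]2CC[C@H](N3CC(OC4CC4)C3)CC2)c2ncncc12`: 6.3 nM

In an assay on HeLa cells for inhibition of histone-lysine N-methyltransferase EZH2 (Homo sapiens), read by AlphaLISA, with a stated time of 72 h (a lower number here means that less compound is needed, a higher number that more compound is needed for the effect), compound 1 gives 1.8 nM, the lowest of the two numbers recorded. Compound 2 gives 6.3 nM in this assay, a higher number, and the gap between the two lies beyond the usual scatter. The two compounds share the remainder of their structure and differ only within the core.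

Compound 3 `CSc1cc(C)[nH]c(=O)c1CNC(=O)c1c(C)n([C@H](C)[C@H]2CC[C@H](N3CC(OC4CC4)C3)CC2)c2ncc(F)cc12` differs from compound 1 by fluoro in place of hydrogen on an aromatic carbon. Among the compounds with values here, no pair of measured compounds differs in exactly this way, so there is no measured step to lean on. A single fluorine in place of a hydrogen on an aromatic carbon usually moves numbers of this kind only a little, so the expected step from compound 1 to compound 3 in this assay is small, a 1.4-fold higher number from compound 1 to compound 3 (0.14 log units; within the scatter), and within the scatter. For compound 3 the estimated value is 2.5 nM, with a range from 1 nM to 6.5 nM.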

Compound 3, half-maximal effective concentration: 1.8 nM
Estimate against measurement, compound 3: 1.4-fold (0.14 log units) above; the range from low to high includes it.
By their numbers in this assay, from the lowest: compounds 1 and 3 (each within the scatter of the next); then compound 2.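

The aromatic carbon two atoms from the ring nitrogen accepts a fluoro in this assay, the step being no change at the digits printed from compound 1 to compound 3 (within the scatter) at this position. Compound 2 differs from compound 1 at this same position, carrying a ring nitrogen in place of that carbon, and compound 2 gives 6.3 nM in the same read-out, so this place in the core does not respond alike to every change, and a fluoro here leaves the number where the hydrogen had it. Nothing measured here accounts for this difference between the two changes.

The compounds shown leave open how this carbon would respond to a chlorine, a methoxy group, a nitrile or an amine. They also leave open whether a fluoro on the other aromatic carbons of that ring would behave as this one does.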